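The source may report more compounds than this note shows. Statements on the series, on what has been measured and on what is new or still open speak of the compounds shown alone.

The study turns on a small set of analogues that share one core. In a functional assay on HeLa cells (Homo sapiens) for inhibition, read by MTT assay (a lower number here means a stronger inhibitor, a higher number a weaker inhibitor), compound 1 `Cc1ccc2c(c1)/C(=N/NC(=S)N/N=C/c1ccccn1)C(=O)N2` gives 3150 nM, the higher of the two numbers obtained. Compound 3 `O=C1Nc2ccc(Br)cc2/C1=N/NC(=S)N/N=C/c1c(F)cccc1Cl` gives 1610 nM in this assay, and the gap between compound 1 and compound 3 stays within the scatter of repeat runs. Compound 2 `COc1ccc(/C=N/NC(=S)N/N=C2\C(=O)Nc3ccc(Br)cc32)c(OC)c1` reaches only a limit of this assay, > 50000 nM. Compound 4 `Cc1ccc(O)c(/C=N/NC(=S)N/N=C2\C(=O)Nc3ccc(C)cc32)c1` differs from compound 1 by 2-hydroxy-5-methylphenyl in place of pyridin-2-yl on a carbon with a double bond to nitrogen. Among the measured compounds shown here, no step between measured compounds of this kind has been recorded, so the direction rests on expectation alone. The expected step of a 1.9-fold higher number from compound 1 to compound 4 (0.28 log units; within the scatter) is a modest loss, somewhat beyond the scatter, given that compound 2 reached a limit (the limit of > 50000 nM in this assay, at which 1 of the 3 values shown sits). The estimate for compound 4 is 6000 nM, with a range from 1500 nM to 30000 nM.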

Compound 4, half-maximal inhibitory concentration: > 50000 nM
Compound 4 was reported as a limit; the forecaster's own chance of this, stated with the estimate: 25%; middle value at least 8.3-fold (0.92 log units) from the limit.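

Among the compounds shown here, compounds 1 to 3 gave no step at this position. The change to 2-hydroxy-5-methylphenyl in place of pyridin-2-yl on a carbon with a double bond to nitrogen now supplies one in this assay, and it is large: an at least 15-fold higher number from compound 1 to compound 4 (1.20 log units; beyond the scatter). The value of compound 4 is a limit of the assay, and it does not stand alone there: the limit of > 50000 nM in this assay, at which 2 of the 4 values shown sit.

On these data alone, whether the hydroxy group or the methyl group of the entering ring carries this loss stays open. So does how a plain phenyl group or a pyridin-3-yl group would fare on this carbon.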